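The compounds below may be only part of what the source reports. "The series", "measured", "known", "first", "only" and "open" are said of these compounds alone.

Of the compounds shown here, three sharing one core have been tested in an ADME assay on HepG2 2.2.15 cells (Homo sapiens) for cytotoxicity; on this read-out higher numbers stand for lower toxicity in this test and lower numbers for higher toxicity in this test. Compound 1 `CC(C)(C)OC(=O)Nc1ncc(C(Oc2ccc(Cc3ccccc3)cc2)c2ccc(Cl)cc2)s1` gives > 50000 nM in this assay, which is a limit of the assay rather than a number. Compound 2 `COc1ccc(Br)c(COC(c2ccccc2)c2cnc(NC(=O)c3cccs3)s2)c1` is reported as "not toxic" (no number reported) in this assay. Compound 3 `CCCCC(CC)CNc1ncc(C(Oc2ccc3cc(Br)ccc3c2)c2ccc(Cl)cc2)s1` is likewise reported as "not toxic" (no number reported) in this assay, so no single number places it against the others; all three measured compounds point to low toxicity, and the only numerical anchor is the limit of > 50000 nM in this assay, at which 1 of the 3 values shown sits. Compound 4 `Cc1ccc(C(=O)Nc2ncc(C(Oc3ccc4cc(Br)ccc4c3)c3ccc(Cl)cc3)s2)cc1` has not yet been measured. It differs from compound 3 in one place: (4-methylphenyl)carbonyl in place of 2-ethylhexyl on a nitrogen on an aromatic ring. For the measured compounds named here, no measured pair differs in a single place, so the step from compound 3 to compound 4 in this assay is expected to be none beyond the scatter. Compound 4 is therefore estimated at 50000 nM in this assay, within 20000 nM to 100000 nM.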

Compound 4, half-maximal cytotoxic concentration: "not toxic" (no number reported)
For compound 4 the study gives words and no number, so the estimate cannot be set against anything.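

For the compounds shown here, compound 3 and compound 4 are both reported only in words as not toxic, so no step between them can be read in this assay. The compounds shown leave open whether swapping 2-ethylhexyl for (4-methylphenyl)carbonyl changes toxicity at all, and only one numerical anchor exists: the limit of > 50000 nM in this assay, at which 1 of the 4 values shown sits.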